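Estimating Compound 3 From Two Sulfonamides at the Limit

A few compounds are considered here, and "the series" means these few. Any claim that something is new, unique, unknown or untested is made for them only; others in the source may bear on it.

Compound 1 `COc1cccc(S(=O)(=O)Nc2ccc3oc(-c4ccccc4)nc3c2)c1` gives > 100000 nM in an assay on cells for inhibition of HSP60/HSP10 (Homo sapiens), with a stated time of 60 min (a lower number here means a stronger inhibitor, a higher number a weaker inhibitor), a limit of the assay.
Compound 2 `O=S(=O)(Nc1ccc2oc(-c3ccccc3)nc2c1)c1ccccc1Cl` gives > 100000 nM in this assay, also a limit.

The step that the two limits leave unreadable from compound 1 to compound 2 cannot be read, since the limit of > 100000 nM in this assay, at which 2 of the 2 values shown sit, holds both values. Compound 2 thus stands only at this limit, with no number of its own. Compound 3 `O=S(=O)(Nc1ccc2oc(-c3ccccc3)nc2c1)c1cccc(O)c1` differs from it by 3-hydroxyphenyl in place of 2-chlorophenyl on a sulfonyl sulfur. For the measured compounds named here, no measured step bears on this change. Compound 3 is therefore expected to stay near the limit, an expected step of a number no higher from compound 2 to compound 3 (the limit leaves the size open) in this assay, with an estimated value of 100000 nM and a range from 20000 nM to 300000 nM.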

Compound 3, half-maximal inhibitory concentration: 76000 nM
Estimate against measurement, compound 3: 1.3-fold (0.12 log units) above, and the stated range covers the measured number.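

For the compounds shown here, with 3-hydroxyphenyl on the sulfonyl sulfur, compound 3 is the first of the three to give a number rather than a limit in this assay, and the step reads an at least 1.3-fold lower number from compound 2 to compound 3 (0.11 log units; that floor lies within the scatter). Hydrogen in place of methyl on an oxygen on an aromatic ring gives an at least 1.3-fold lower number from compound 1 to compound 3 (0.11 log units; that floor lies within the scatter). Both steps are floors, and the other two compounds give no number of their own: the limit of > 100000 nM in this assay, at which 2 of the 3 values shown sit.

The compounds shown leave open the true size of both steps. They also leave open whether an amine or a carboxylic acid in place of the hydroxy group would give a lower number.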